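From Aminophenyl to Difluorophenyl on the Carbonyl Carbon

The compounds below may be only part of what the source reports. "The series", "measured", "known", "first", "only" and "open" are said of these compounds alone.

Compound 1 `COc1cc(-c2cc(/C=C/C(=O)c3ccc(N)cc3)[nH]n2)cc(OC)c1OC` carries a 4-aminophenyl on the carbonyl carbon. Within the data shown here, in a functional assay on OVCAR-8 cells (Homo sapiens) for cytotoxicity, read by sulforhodamine B assay, with a stated time of 48 h, tested at 10 uM (a higher number here means a weaker effect of the compound at the concentration tested, a lower number a stronger effect), compound 1 gives -1%, the lowest of the two numbers so far, with compound 2 as its nearest neighbour. Compound 2 `COc1cc(-c2cc(/C=C/C(=O)c3ccc(Cl)c(Cl)c3)[nH]n2)cc(OC)c1OC`, which puts a 3,4-dichlorophenyl in that place, gives 40% in this assay. Among the measured compounds shown here, the one step that has been measured, a number 41 percentage points higher from compound 1 to compound 2 (beyond the scatter), is large and points upward, so the aminophenyl compound is the more active of the pair.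

Compound 3 `COc1cc(-c2cc(/C=C/C(=O)c3ccc(F)c(F)c3)[nH]n2)cc(OC)c1OC` is not yet measured. Its difference from compound 1 is 3,4-difluorophenyl in place of 4-aminophenyl on a carbonyl carbon. For the measured compounds named here, only the step from compound 1 to compound 2 bears on this change; both replace the 4-aminophenyl with a dihalophenyl on the carbonyl carbon, though the halogen differs. Going by the values given here, a step in the same direction is therefore expected in this assay, likely somewhat smaller than the dichlorophenyl step because a number 41 percentage points higher from compound 1 to compound 2 (beyond the scatter) is the sole guide and the fluorine analogue is untested. The estimate is a number 26 percentage points higher from compound 1 to compound 3 (beyond the scatter). For compound 3 the expected value is 25%, within 0% to 50%.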

Compound 3, a percentage reported as activity, at one concentration (the size of the read-out at that concentration, not a potency): 4%
Compound 3: the middle estimate sits 21 percentage points above what was measured; low and high end bracket the measured number.
By their numbers in this assay, from the lowest: compounds 1 and 3 (each within the scatter of the next); then compound 2.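

In this assay, the step of a number 5 percentage points higher from compound 1 to compound 3 (within the scatter) shows that the 4-aminophenyl on the carbonyl carbon can give way to a ring with no hydrogen-bond donor without a readable change, so among these compounds the amino group is not required for the effect. The halogen now carries the difference: the step of a number 36 percentage points lower from compound 2 to compound 3 (beyond the scatter) separates two dihalophenyl groups in the same place, and the large step seen earlier therefore goes with the 3,4-dichlorophenyl and not with the loss of the 4-aminophenyl as such. Nothing at hand explains why the 3,4-difluorophenyl and the 3,4-dichlorophenyl part so widely.

An unsubstituted phenyl, a bromophenyl or a methoxyphenyl on the carbonyl carbon would show whether the compounds with the stronger effect or compound 2 is the exception at this position. On these data alone, with a read-out at a single concentration, compounds 1 and 3 cannot be told apart, and any difference in potency between them remains open.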